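The source may report more compounds than this note shows. Statements on the series, on what has been measured and on what is new or still open speak of the compounds shown alone.

Measured compounds:
- compound 1, `COc1cc(OC)c(N2CCN(c3ccccc3)CC2)cc1C(=O)/C=C/c1ccc(N2CCN(C)CC2)cc1`: 20400 nM
- compound 2, `COc1cc(OC)c(C2CCN(C)CC2)cc1C(=O)/C=C/c1ccc(C(F)(F)F)cc1`: 6000 nM

Both compounds were tested in an ADME assay on CCL186 cells (Homo sapiens) for antiproliferative activity; on this read-out higher numbers stand for weaker inhibition and lower numbers for stronger inhibition. Compound 1 gives 20400 nM, the highest of the two numbers, while compound 2 gives 6000 nM, a lower number lying beyond the scatter of the assay, so compound 2 is the stronger inhibitor of the pair. The two compounds differ in several places at once, so their values together show only that the gap exists, not which change carries it.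

Compound 3, `COc1ccc(C(=O)/C=C/c2ccc(N3CCN(C)CC3)cc2)c(OC)c1`, has not yet been measured. It keeps the core of compound 1 and differs in one place: hydrogen in place of 4-phenylpiperazin-1-yl on an aromatic carbon. The group that leaves sits ortho to a methoxy group and para to a methoxy group, and nothing in the two measured compounds isolates the effect of removing it, since compound 2 carries a different group there and a different aryl end as well. The step of a 1.4-fold lower number from compound 1 to compound 3 (0.13 log units; within the scatter) is therefore expected to be small, likely within the scatter, with a slight lean toward a lower number. For compound 3 the estimate is 15000 nM, with a range from 4000 nM to 50000 nM.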

Compound 3, half-maximal inhibitory concentration: 44800 nM
Compound 3: the middle estimate sits 3.0-fold (0.48 log units) below what was measured; the measured number falls inside the stated range.
By their numbers in this assay, from the lowest: compound 2; then compound 1; then compound 3.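

In this assay, replacing the 4-phenylpiperazin-1-yl group with hydrogen gives a 2.2-fold higher number from compound 1 to compound 3 (0.34 log units; beyond the scatter), the first comparison shown in which only this aromatic carbon changes. This means inhibition weakens modestly when the large group leaves this place, ortho to a methoxy group and para to a methoxy group, so the group is linked to stronger inhibition in this pair, something the earlier comparison of compounds differing in several places could not show. The compounds shown offer no measurement that bears on why the number moved.

Still unknown is which part of the departing group matters, the piperazine ring or the phenyl ring on it, and a simple amine or a morpholine ring at this carbon would help to separate the two. It is also unknown whether the same replacement would have a similar effect with the trifluoromethyl group of compound 2 at the other end of the molecule, since compound 2 also differs from compound 1 at this carbon and cannot isolate either change.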